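This account rests on a few compounds, and the source may have more. Where it says the series, first, only, none or still open, it means among the compounds named here.

Three compounds from one series share a core; in an assay for inhibition of Pro-cathepsin H (Homo sapiens), read by fluorescence, tested at 50 uM (a higher number here means more inhibition at the concentration tested (going by the name of the read-out), a lower number less inhibition), compound 1 `O=c1nc(SCc2ccccc2)nc(SCc2ccccc2F)[nH]1` gives "not determined" (no result reported), so no number is reported for it. In this assay compound 2 `O=c1nc(SCc2ccccc2)nc(SCc2cccc(F)c2)[nH]1` gives 4.18%, and compound 3 `N#Cc1ccc(CSc2nc(SCc3ccccc3)nc(=O)[nH]2)cc1` gives 1.55%. Compound 3 therefore stands at the lower of the two numbers, but the step of a number 2.6 percentage points lower from compound 2 to compound 3 (within the scatter) lies within the scatter, so the two cannot be ranked against each other.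

Compound 4 `O=C(O)CSc1nc(SCc2ccccc2)nc(=O)[nH]1` differs from compound 3 in one place: carboxy in place of 4-cyanophenyl on a saturated chain carbon bound to a sulfur. For the measured compounds named here, the only measured step that bears on this is the exchange of one aromatic group for another from compound 2 to compound 3, which produced no change beyond the scatter. Going by the values given here, the present exchange is larger, swapping a ring for a small acid, and no measured pair shows such a swap, so it offers no footing for a shift in either direction. Both measured numbers sit close to zero, and the expectation for compound 4 is a step of a number 1.5 percentage points higher from compound 3 to compound 4 (within the scatter), within the scatter. Compound 4 is thus estimated at 3%, with a range from -5% to 12%.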

Compound 4, a percentage reported as inhibition, at one concentration (the size of the read-out at that concentration, not a potency): 6.89%
Compound 4: the middle estimate sits 3.9 percentage points below what was measured, and the stated range covers the measured number.
By their numbers in this assay, from the lowest: compounds 3, 2 and 4 (each within the scatter of the next).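

Replacing the aromatic ring on a saturated chain carbon bound to a sulfur with carboxy, a much smaller group with no ring, does not produce a difference that can be told from the scatter in this assay. For the compounds shown here, this holds against both aromatic groups measured there, 4-cyanophenyl (a number 5.3 percentage points higher from compound 3 to compound 4 (within the scatter)) and 3-fluorophenyl (a number 2.7 percentage points higher from compound 2 to compound 4 (within the scatter)), whereas the earlier step compared only one aromatic group with another. No measurement at hand explains this result.

On these data alone, whether an amine, or a longer chain carrying the carboxylic acid, would give a number clearly apart from those of compound 2, compound 3 and compound 4 stays open. So does the place of compound 1, which has no reported number, and with it any effect of 2-fluorophenyl at this position.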